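This account rests on a few compounds, and the source may have more. Where it says the series, first, only, none or still open, it means among the compounds named here.

Among the compounds with values here, compound 3 `COc1ccc(/C=C/C(=O)OC[C@@H](OCc2ccccc2)[C@H]2OC(=O)C=C[C@H]2OCc2ccccc2)cc1` gives 4250 nM in a functional assay on A549 cells (Homo sapiens) for antiproliferative activity, read by MTT assay, with a stated time of 6 days (a higher number here means a weaker inhibitor, a lower number a stronger inhibitor), the lowest of the three numbers so far; compound 2 `CC(=O)O[C@@H]1C=CC(=O)O[C@@H]1[C@@H](COC(=O)c1ccc([N+](=O)[O-])cc1)OC(C)=O` gives 8640 nM and compound 1 `CC(=O)O[C@@H]1C=CC(=O)O[C@@H]1[C@@H](COC(=O)c1ccc(Cl)cc1)OC(C)=O` gives 15700 nM, both standing beyond the scatter above compound 3. Compound 4 `O=C1C=C[C@@H](OCc2ccccc2)[C@@H]([C@@H](COC(=O)/C=C/c2ccc([N+](=O)[O-])cc2)OCc2ccccc2)O1` differs from compound 3 by nitro in place of methoxy on an aromatic carbon. Within the data shown here, the only measured step that bears on a change to nitro is the one a 1.8-fold lower number from compound 1 to compound 2 (0.26 log units; within the scatter), although there chloro leaves rather than methoxy, and those two compounds sit on the core of compound 1 rather than that of compound 3. That step lay within the scatter, so for compound 4 little movement beyond the scatter in this assay is expected, if anything a slightly lower number, the estimated step being a 1.3-fold lower number from compound 3 to compound 4 (0.12 log units; within the scatter). Compound 4 is therefore expected at 3200 nM, within 1200 nM to 8500 nM.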

Compound 4, half-maximal inhibitory concentration: 5240 nM
Estimate against measurement, compound 4: 1.6-fold (0.21 log units) below; the measured number falls inside the stated range.
By their numbers in this assay, from the lowest: compounds 3, 4, 2 and 1 (each within the scatter of the next, the first and the last beyond it).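

Going from 4-methoxyphenyl to 4-nitrophenyl on the core of compound 3 in this assay gives a 1.2-fold higher number from compound 3 to compound 4 (0.09 log units; within the scatter) and so leaves the number within the scatter. The earlier step to nitro, a 1.8-fold lower number from compound 1 to compound 2 (0.26 log units; within the scatter) on the core of compound 1 with chloro leaving, also stayed within the scatter, so nitro has now been read on both cores without a step beyond it. No evidence on hand bears on this result.

On these data alone, whether an amine or a carboxylic acid in the same place on the ring would move the number beyond the scatter stays open. Also open, as far as these compounds go, is whether a shorter chain in place of the ethenyl link would change the picture.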